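Closing the Amine into a Ring on an Amide Side Chain

The source may report more compounds than this note shows. Statements on the series, on what has been measured and on what is new or still open speak of the compounds shown alone.

Compound 1, `COc1ccc(-c2nc3cc(C(F)(F)F)ccc3[nH]2)cc1`, in an ADME assay on MDBK cells (Bos taurus) for cytotoxicity, read by MTT assay, with a stated time of 96 h; a higher number here means that more compound is tolerated, a lower number that less compound is tolerated: compound 1 gives > 100000 nM.
Compound 2, `CCN(CC)CC(=O)Nc1ccc(-c2nc3cc(C(F)(F)F)ccc3[nH]2)cc1`: compound 2 gives 13000 nM.

The value for compound 1 is a limit of the assay, not a number, as the evidence states (the limit of > 100000 nM in this assay, at which 1 of the 2 values shown sits). Among the compounds with values here, compound 2 therefore stands as the only compound with an actual number in this assay, and it is tolerated less than the limit reached by compound 1. Within the data shown here, the single measured step, an at least 7.6-fold lower number from compound 1 to compound 2 (0.88 log units; beyond the scatter), comes with (((diethylamino)methyl)carbonyl)amino in place of methoxy on an aromatic carbon.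

Compound 3, `O=C(CN1CCCCC1)Nc1ccc(-c2nc3cc(C(F)(F)F)ccc3[nH]2)cc1`, is built from compound 2 by a smaller change: piperidin-1-yl in place of diethylamino on a saturated chain carbon bound to a carbonyl carbon. Among the measured compounds shown here, no measured step bears on this kind of exchange, since the only one recorded swaps the whole side chain rather than the amine at its end. With nothing in the data pointing either way, the step of no change at the digits printed from compound 2 to compound 3 (within the scatter) in this assay is expected to stay within the usual scatter. Compound 3 is therefore estimated at 13000 nM, with a plausible range from 5000 nM to 35000 nM.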

Compound 3, half-maximal cytotoxic concentration: 6000 nM
The estimate for compound 3 lay 2.2-fold (0.34 log units) above the measured number; the measured number falls inside the stated range.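

Changing only the amine at the end of the side chain is enough to move the result in this assay, with a 2.2-fold lower number from compound 2 to compound 3 (0.34 log units; beyond the scatter) on going from diethylamino to piperidin-1-yl; the earlier step exchanged the whole side chain, so it could not show this. The two groups have the same hydrogen-bond donor and acceptor counts, and both are uncharged as computed, but the entering group is a six-membered non-aromatic ring with one more carbon, so closing the amine into a ring lowers the tolerated concentration in this single pair. Nothing shown here explains why this exchange lowers the number.

A single pair cannot separate the effect of forming the ring from that of adding a carbon, and a five-membered pyrrolidin-1-yl group or a morpholin-4-yl group, with an oxygen in the ring, would help to tell these apart. Going by these compounds, it also remains open whether the same exchange would give a similar step with a longer chain between the carbonyl and the amine, or with a simple dimethylamino group at the end.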